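Swapping the alkyne aryl group for a pyridine ring

The compounds below may be only part of what the source reports. "The series", "measured", "known", "first", "only" and "open" are said of these compounds alone.

Measured so far:
compound 1 `Cc1cccc(C#Cc2ccc3c(n2)CCN(C(C)C)C3=O)c1` gives 4.8 nM
compound 2 `CC(C)N1CCc2nc(C#Cc3ccc(Cl)cc3)ccc2C1=O` gives 4230 nM

Two compounds share one core and differ only in the aryl group on the triple-bonded carbon. In a functional assay on HEK293 cells for negative allosteric modulation of metabotropic glutamate receptor 5 (Homo sapiens), read by FLIPR and calcium flux (a higher number here means a weaker inhibitor, a lower number a stronger inhibitor), compound 1 carries a 3-methylphenyl group and gives 4.8 nM. Compound 2 carries a 4-chlorophenyl group in its place and gives 4230 nM, which is the higher of the two numbers and so the weaker inhibitor of the pair. Among the measured compounds shown here, the single measured step, an 880-fold higher number from compound 1 to compound 2 (2.95 log units; beyond the scatter), shows that this one position can move the read-out by a very large amount.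

Compound 3 `CC(C)N1CCc2nc(C#Cc3ccccn3)ccc2C1=O` is not yet measured. It differs from compound 2 by pyridin-2-yl in place of 4-chlorophenyl on a triple-bonded carbon. The step from compound 1 to compound 2 is the only one that bears on it, and it was large, so a large step is plausible here too; its direction is not fixed by the data. Given that compound 2 stands at the weak end, the expected step is a 28-fold lower number from compound 2 to compound 3 (1.45 log units; beyond the scatter), toward stronger inhibition. Compound 3 is therefore estimated at 150 nM, within a range from 15 nM to 1500 nM.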

Compound 3, half-maximal inhibitory concentration: 27 nM
Compound 3: middle estimate off by 5.6-fold (0.74 log units), on the high side, and the stated range covers the measured number.
By their numbers in this assay, from the lowest: compound 1; then compound 3; then compound 2.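

In this assay, this position on the triple-bonded carbon now has a third aryl group, and the change to pyridin-2-yl, a ring with a nitrogen in it and no other substituent, gives a 160-fold lower number from compound 2 to compound 3 (2.19 log units; beyond the scatter). This shows that a strong inhibitor at this position does not need a carbon-only ring, and it places the 4-chlorophenyl group of compound 2 as the clear outlier of the three, although pyridin-2-yl does not fully match 3-methylphenyl: the comparison gives a 5.6-fold higher number from compound 1 to compound 3 (0.75 log units; beyond the scatter), a modest step but one beyond the scatter. No supporting measurement accompanies these numbers to explain why the three groups rank as they do.

The compounds shown cannot separate the effect of the chlorine from that of where each substituent sits on the ring, since 3-methylphenyl and 4-chlorophenyl differ in both. A plain phenyl group, or a pyridin-2-yl ring carrying a methyl group, would help to tell whether the ring nitrogen and the methyl group each contribute on their own.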